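The compounds below may be only part of what the source reports. "The series", "measured", "known", "first", "only" and "open" are said of these compounds alone.

In an assay on MDA-MB-231 cells for binding affinity to C-X-C chemokine receptor type 4 (Homo sapiens), read by microscopy, with stated times of 10 min and 30 min (on this read-out lower numbers stand for an effect already at smaller amounts and higher numbers for an effect only at larger amounts of compound), compound 1 `O=C(NCc1ccc(CNS(=O)(=O)c2ccc(Cl)cc2)cc1)c1ccc(CNc2ncccn2)cc1` gives 100 nM. Compound 2 `O=C(NCc1ccc(CNS(=O)(=O)c2cccnc2)cc1)c1ccc(CNc2ncccn2)cc1` differs from it only on the sulfonyl sulfur, where pyridin-3-yl stands in place of 4-chlorophenyl, and that change, an at least 10-fold higher number from compound 1 to compound 2 (1.00 log units; beyond the scatter), is beyond the scatter. For compound 2 the assay reports only a limit, > 1000 nM, so its position is fixed only by the limit of > 1000 nM in this assay, at which 1 of the 2 values shown sits. Compound 3 `Cc1ccc(S(=O)(=O)NCc2ccc(CNC(=O)c3ccc(CNc4ncccn4)cc3)cc2)cc1` continues from compound 2 with 4-methylphenyl in place of pyridin-3-yl on a sulfonyl sulfur: a six-membered aromatic ring of carbon only returns to the sulfonyl sulfur, where compound 1 also carries one. Within the data shown here, the single measured step that bears on this change ran the other way and lost at least modestly, so the reverse change is expected to regain a similar amount, putting the step from compound 2 to compound 3 at an estimated at least 6.6-fold lower number from compound 2 to compound 3 (0.82 log units; beyond the scatter). Compound 3 is therefore expected to give about 150 nM, within a range of 50 nM to 600 nM.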

Compound 3, effective concentration (reported as EC, without a stated level of effect): 100 nM
Estimate against measurement, compound 3: 1.5-fold (0.18 log units) above; the measured number falls inside the stated range.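

Methyl in place of chloro on an aromatic carbon gives no change at the digits printed from compound 1 to compound 3 (within the scatter), so the chloro group itself is not needed for the value seen with compound 1. Returning from pyridin-3-yl to a six-membered aromatic ring of carbon only gives an at least 10-fold lower number from compound 2 to compound 3 (1.00 log units; beyond the scatter), which shows that the earlier loss is also reversed by a ring carrying a different group. For compound 2, the size of this step rests only on a limit: the limit of > 1000 nM in this assay, at which 1 of the 3 values shown sits.

The compounds shown leave open whether the poor result of compound 2 comes from its ring nitrogen or from the lack of a chloro or methyl group, a question that plain phenyl on the sulfonyl sulfur would help to settle. As far as these compounds go, how a methoxy group, a larger ethyl group or a saturated cyclohexyl ring would fare at this place also remains open.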